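Acid head group swap on the shared core

The source may report more compounds than this note shows. Statements on the series, on what has been measured and on what is new or still open speak of the compounds shown alone.

Compound 1 `COc1cc(OC(F)(F)F)cc(-c2ccc3c(c2)CC[C@H](CCc2nnn[nH]2)O3)c1F` and compound 2 `Fc1ccc(OC(F)(F)F)cc1-c1ccc2c(c1)CC[C@H](CCc1nnn[nH]1)O2` carry the same tetrazolylethyl chain on the shared core and differ by methoxy against hydrogen on an aromatic carbon. In a functional assay on HEK293 cells for agonist activity at Free fatty acid receptor 1 (Homo sapiens), read by HTRF and inositol phosphate accumulation, with a stated time of 60 min (a higher number here means that more compound is needed for the effect, a lower number that less compound is needed), compound 1 gives only a limit, > 10000 nM. In this assay compound 2 likewise gives only a limit, > 10000 nM. The step that the two limits leave unreadable from compound 1 to compound 2 is therefore not readable, as both ends sit at the limit of > 10000 nM in this assay, at which 2 of the 2 values shown sit. Compound 2 thus stands at the limit, with no number to place it against compound 1.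

Compound 3 `O=C(O)[C@H]1C[C@@H]1[C@H]1CCc2cc(-c3cc(OC(F)(F)F)ccc3F)ccc2O1` differs from compound 2 by 2-carboxycyclopropyl in place of 2-(1H-tetrazol-5-yl)ethyl on a saturated ring carbon. Among the measured compounds shown here, no measured step touches this position; the only measured step lies on the aromatic ring and is itself unreadable. For the measured compounds named here, there is hence no measured step on which to size the change in this assay; the expectation rests on compound 2 alone, and a value at the limit remains the likeliest outcome. The step of an at least 1.2-fold lower number from compound 2 to compound 3 (0.09 log units; that floor lies within the scatter) is expected to be modest in this assay, if readable at all. For compound 3 the estimated value is 8000 nM, with a range from 500 nM to 30000 nM.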

Compound 3, half-maximal effective concentration: > 10000 nM
Compound 3: a limit, no number; the forecaster's own chance of this, stated with the estimate: 55%; middle value at least 1.2-fold (0.09 log units) away from the limit.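

No new step can be read: compound 2 and compound 3 both give only a limit, not a number, in this assay: the limit of > 10000 nM in this assay, at which 3 of the 3 values shown sit.

The compounds shown leave open what 2-carboxycyclopropyl against 2-(1H-tetrazol-5-yl)ethyl, or methoxy against hydrogen, does to the value in this assay, with no number yet on the series from any of the three.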